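Swapping hydroxy for trifluoromethyl on the aryl group

The compounds below may be only part of what the source reports. "The series", "measured", "known", "first", "only" and "open" are said of these compounds alone.

Of the compounds shown here, three sharing a common core have been tested in an assay on HL-60 cells for inhibition of glutathione S-transferase P (Homo sapiens); on this read-out higher numbers stand for weaker inhibition and lower numbers for stronger inhibition. Compound 1 `C=C(C)C(=O)c1ccc(OCc2nc(-c3ccc(C(F)(F)F)cc3)no2)cc1C` gives 3300 nM. Compound 2 `C=C(C)C(=O)c1ccc(OCc2nc(C)no2)c(C)c1C` gives 4000 nM, and compound 3 `C=C(C)C(=O)c1ccc(OCc2nc(-c3ccc(O)cc3)no2)c(C)c1C` gives 3400 nM. Compound 3 sits second of the three numbers, but all three lie within the scatter of one another, so no order among them can be read. For the measured compounds named here, the one step that can be traced, a 1.2-fold lower number from compound 2 to compound 3 (0.07 log units; within the scatter), exchanges methyl for 4-hydroxyphenyl and stays within the scatter.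

Compound 4 `C=C(C)C(=O)c1ccc(OCc2nc(-c3ccc(C(F)(F)F)cc3)no2)c(C)c1C` is the next candidate. Its change from compound 3 is trifluoromethyl in place of hydroxy on an aromatic carbon. Going by the values given here, no measured step exchanges hydroxy for trifluoromethyl directly, so the only guide is that compound 1, which carries the same 4-(trifluoromethyl)phenyl group on a differently substituted core, gives 3300 nM, a number indistinguishable from that of compound 3. The expectation for this assay is therefore no step beyond the scatter, which means the estimated step is a 1.0-fold lower number from compound 3 to compound 4 (0.01 log units; within the scatter). Compound 4 is expected to give about 3300 nM, within a range from 1500 nM to 7500 nM.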

Compound 4, half-maximal inhibitory concentration: 3900 nM
The estimate for compound 4 lay 1.2-fold (0.07 log units) below the measured number, within the range that was stated.
By their numbers in this assay, from the lowest: compounds 1, 3, 4 and 2 (each within the scatter of the next).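

In this assay, trifluoromethyl in place of hydroxy on the aryl ring gives a 1.1-fold higher number from compound 3 to compound 4 (0.06 log units; within the scatter) even though the hydrogen-bond donor is lost, so this exchange at this place, para to a large group, shows no effect that can be read. The same holds for two wider comparisons: the whole 4-(trifluoromethyl)phenyl group in place of methyl gives a 1.0-fold lower number from compound 2 to compound 4 (0.01 log units; within the scatter) on the shared core, and methyl in place of hydrogen on an aromatic carbon of the core gives a 1.2-fold higher number from compound 1 to compound 4 (0.07 log units; within the scatter) in this series. No further data offer an explanation for these small steps.

As far as these compounds go, it remains open whether an amine or a carboxylic acid at this place would give a step beyond the scatter. The same question stands for a longer chain in place of the aryl group.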